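A few compounds are considered here, and "the series" means these few. Any claim that something is new, unique, unknown or untested is made for them only; others in the source may bear on it.

Compound 1 `COc1cc2c(c(O)c1C(=O)/C=C/c1ccc(OC(C)=O)cc1)CCC(C)(C)O2`, compound 2 `C=CC(=O)Oc1ccc(/C=C/C(=O)c2c(OC)cc3c(c2O)CCC(C)(C)O3)cc1` and compound 3 `COc1cc2c(c(OC(C)=O)c1C(=O)/C=C/c1ccc(OC(C)=O)cc1)CCC(C)(C)O2` share one core and were tested in an assay on HEK293T cells for inhibition of nuclear factor NF-kappa-B complex (Homo sapiens), read by a luciferase reporter; a lower number here means a stronger inhibitor, a higher number a weaker inhibitor. For compound 1 this assay gives only a limit, > 30000 nM. For compound 3 this assay likewise gives only a limit, > 30000 nM. Compound 2 gives 8990 nM. The change from compound 1 to compound 2 is vinyl in place of methyl on a carbonyl carbon, and it made an at least 3.3-fold lower number from compound 1 to compound 2 (0.52 log units; beyond the scatter). The change from compound 1 to compound 3 is acetyl in place of hydrogen on an oxygen on an aromatic ring, and it made a step that the two limits leave unreadable from compound 1 to compound 3, since the limit of > 30000 nM in this assay, at which 2 of the 3 values shown sit, hides its size. Compound 4 `C=CC(=O)Oc1c2c(cc(OC)c1C(=O)/C=C/c1ccc(OC(C)=O)cc1)OC(C)(C)CC2` is not yet measured; its change from compound 3 is vinyl in place of methyl on a carbonyl carbon, the same change as from compound 1 to compound 2. The step is expected to be an at least 2.0-fold lower number from compound 3 to compound 4 (0.30 log units; that floor lies within the scatter) because the same change earlier made an at least 3.3-fold lower number from compound 1 to compound 2 (0.52 log units; beyond the scatter). In this assay compound 4 is expected to give 15000 nM.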

Compound 4, half-maximal inhibitory concentration: 1040 nM
Beside the measured number, compound 4's estimate is 14-fold (1.16 log units) above it; measured number outside the range, below it.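

In this assay vinyl in place of methyl on a carbonyl carbon gives an at least 28-fold lower number from compound 3 to compound 4 (1.46 log units; beyond the scatter) and so repeats the direction seen on the first pair. A second change in one place likewise gives an at least 28-fold lower number from compound 1 to compound 4 (1.46 log units; beyond the scatter) and reaches the same lower number by a different route. The change therefore carried over in direction between the two cores shown, but this does not show that its size carried over:
the same change on two cores in this assay, an at least 3.3-fold lower number (0.52 log units; beyond the scatter) from compound 1 to compound 2 and an at least 28-fold lower number (1.46 log units; beyond the scatter) from compound 3 to compound 4; the limit leaves it open whether they differ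

The compounds shown leave open how an ethyl group in place of the vinyl would read in this assay, which would test whether the double bond counts. They also leave open whether the change would act the same way on any further core.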